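The source may hold more compounds than are shown below. What is called first, only, known or untested is meant among the compounds shown, and "the series" means these compounds.

Among the compounds with values here, compound 1 `O=C(NCCCCc1ccccc1)n1cc(-c2ccc(F)cc2)oc1=O` has the highest of the two numbers so far in an assay on isolated protein for inhibition of acid ceramidase (Homo sapiens), read by LC-MS, with a stated time of 1 h (a higher number here means a weaker inhibitor, a lower number a stronger inhibitor), where compound 1 gives 185 nM. Compound 2 `O=C(NCCCCc1ccccc1)n1cc(-c2cscn2)oc1=O` gives 44 nM, and the change from compound 1 to compound 2 brought a 4.2-fold lower number from compound 1 to compound 2 (0.62 log units; beyond the scatter). Compound 3 `CN1CCC(c2cc(-c3cn(C(=O)NCCCCc4ccccc4)c(=O)o3)ccc2F)CC1` differs from compound 1 by 1-methylpiperidin-4-yl in place of hydrogen on an aromatic carbon. Within the data shown here, no measured step concerns this kind of addition; the only step known exchanges the aromatic group itself, so it offers no direct guide. Compound 3 is therefore expected to show a 1.5-fold lower number from compound 1 to compound 3 (0.19 log units; within the scatter), a step expected to stay near the scatter. Compound 3 is estimated at 120 nM, within 40 nM to 400 nM.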

Compound 3, half-maximal inhibitory concentration: 341 nM
Compound 3: middle estimate off by 2.8-fold (0.45 log units), on the low side, and the stated range covers the measured number.
By their numbers in this assay, from the lowest: compound 2; then compounds 1 and 3 (each within the scatter of the next).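

In this assay the addition of 1-methylpiperidin-4-yl ortho to a fluoro group brings a 1.8-fold higher number from compound 1 to compound 3 (0.27 log units; within the scatter) and so no change beyond the scatter. This aromatic carbon therefore carries a whole non-aromatic ring without a clear loss, which the earlier exchange of the aromatic group could not show. Nothing measured here explains this result. As far as these compounds go, it remains open whether a smaller amine such as dimethylamino, or a carboxylic acid, at this carbon would read the same. From the compounds shown here alone, it also remains open whether 1-methylpiperidin-4-yl would be carried equally well on the 1,3-thiazol-4-yl group of compound 2.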